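Shifting a Methyl Around the Ring of Compound 1

A few compounds are considered here, and "the series" means these few. Any claim that something is new, unique, unknown or untested is made for them only; others in the source may bear on it.

Compound 1 `N/C(=N\NC(=S)N1CCOCC1)c1ccccn1` is tested in a functional assay on HeLa cells (Homo sapiens) for cytotoxicity, read by MTT assay, with a stated time of 72 h, tested at 1 uM (a lower number here means less inhibition of growth, a higher number more inhibition of growth at the concentration tested), and gives 12.7%. That is the lowest of the three numbers measured; its nearest neighbour is compound 3 `N/C(=N\NC(=S)N1CCCCC1)c1ccccn1`, which gives 15.5%, a move of a number 2.8 percentage points higher from compound 1 to compound 3 (within the scatter). The furthest is compound 2 `Cc1ccnc(/C(N)=N/NC(=S)N2CCOCC2)c1`, which gives 39.1%, a move of a number 26.4 percentage points higher from compound 1 to compound 2 (beyond the scatter).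

Compound 4 `Cc1cccc(/C(N)=N/NC(=S)N2CCOCC2)n1` is not yet measured. It differs from compound 1 in a single place: methyl in place of hydrogen on an aromatic carbon. The methyl in compound 4 sits next to the ring nitrogen, meta to a large group, while the methyl of compound 2 sits in a different place on the same ring. Within the data shown here, the step from compound 1 to compound 2 is therefore the only measured step that bears on this change, and it was modest but beyond the scatter. The step to compound 3 concerns a different part of the molecule and does not inform this move.

A change in the place of the methyl gives no firm guide, so the expectation is an increase smaller than that seen for compound 2, with wide uncertainty. Compound 4 is expected to give 25%, within 8% to 45%. The expected step is a number 12.3 percentage points higher from compound 1 to compound 4 (beyond the scatter).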

Compound 4, percent growth inhibition at one concentration: 25.7%
Beside the measured number, compound 4's estimate is 0.7 percentage points below it; the range from low to high includes it.
By their numbers in this assay, from the lowest: compounds 1 and 3 (each within the scatter of the next); then compound 4; then compound 2.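

In this assay, among these compounds, a methyl next to the ring nitrogen also raises the number, with a number 13 percentage points higher from compound 1 to compound 4 (beyond the scatter), so the gain seen for compound 2 is not confined to the one ring place that compound carries its methyl on. The place still counts: with the same added group, compound 2 gives 39.1% and compound 4 gives 25.7%, so moving the methyl around the ring changes how much growth inhibition is gained. Nothing measured here explains why a methyl has this effect at either place.

Going by these compounds, it remains open whether an ethyl chain, an amine or a chlorine atom at this same place would raise the number further or lower it. Also open, on these data alone, is whether this methyl would give a similar step on a compound carrying piperidin-1-yl instead of morpholin-4-yl.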